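The source may report more compounds than this note shows. Statements on the series, on what has been measured and on what is new or still open speak of the compounds shown alone.

Measured so far:
compound 1, `c1ccc(C(c2c[nH]c3ccccc23)c2c[nH]c3ccccc23)cc1`, 40000 nM
compound 2, `Oc1cccc(C(c2c[nH]c3ccc(Br)cc23)c2c[nH]c3ccc(Br)cc23)c1`, 8000 nM

Both compounds were tested in a functional assay on A549 cells (Homo sapiens) for inhibition, read by MTT assay, with a stated time of 48 h; on this read-out lower numbers stand for stronger inhibition and higher numbers for weaker inhibition. For the measured compounds named here, compound 2 stands at the lowest number of the two; compound 1 gives the only other value, a higher one, and that gap lies beyond the usual scatter of the measurement. Nothing more than these two values is known, and no stepwise comparison between them is available.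

Compound 3, `COc1cccc(C(c2c[nH]c3ccc(Br)cc23)c2c[nH]c3ccc(Br)cc23)c1OC`, has not yet been measured in this assay. It differs from compound 2 in one place: 2,3-dimethoxyphenyl in place of 3-hydroxyphenyl on a saturated chain carbon bound to two aromatic carbons. Going by the values given here, since no measured step of this kind is available, the expectation rests only on the position of compound 2 in this assay and on the nature of the change. The step from compound 2 to compound 3 is expected to be a 1.5-fold higher number from compound 2 to compound 3 (0.18 log units; within the scatter), a moderate rise in the number, though a result within the scatter would not be surprising. Compound 3 is therefore estimated at 12000 nM in this assay, with a likely range from 4000 nM to 40000 nM.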

Compound 3, half-maximal inhibitory concentration: 100000 nM
Beside the measured number, compound 3's estimate is 8.3-fold (0.92 log units) below it, and the stated range ends below it.
By their numbers in this assay, from the lowest: compound 2; then compound 1; then compound 3.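

In this assay the exchange of 3-hydroxyphenyl for 2,3-dimethoxyphenyl on the saturated chain carbon bound to two aromatic carbons gives a 13-fold higher number from compound 2 to compound 3 (1.10 log units; beyond the scatter) and so marks a large move toward weaker inhibition, well beyond the scatter. For the compounds shown here, this is the only measured step at this position, and it shows that the read-out is sensitive to the group placed there, which the two earlier values, lacking any single-place comparison, could not show. The change swaps the hydrogen-bond donor of 3-hydroxyphenyl for a group with none and adds heavy atoms, but the one step cannot separate these differences, and no measurement shown accounts for the rise in the number.

The compounds shown leave open whether the loss of the hydroxyl or the added methoxy groups matters more, a question that a single methoxy group on the same phenyl ring could address. They also leave open how an amine or a carboxylic acid on that ring would compare with compound 2 in this assay under the same conditions.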